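A few compounds are considered here, and "the series" means these few. Any claim that something is new, unique, unknown or untested is made for them only; others in the source may bear on it.

Working notes on the series. In a functional assay on PC-3 cells (Homo sapiens) for antiproliferative activity (a lower number here means a stronger inhibitor of growth, a higher number a weaker inhibitor of growth), compound 1 `Cc1ccnc2nc(-c3cccc(Cl)c3)cc(O)c12` gives 15.5 nM. Compound 2 `Cc1ccc2c(O)cc(-c3cccc(Cl)c3)nc2n1` gives > 100000 nM, and this reading is a limit of the assay, not a number. Compound 2 therefore has no exact place on the scale, and the evidence so far reads: the limit of > 100000 nM in this assay, at which 1 of the 2 values shown sits.

Compound 3 `Cc1cccc(-c2cc(O)c3ccc(C)nc3n2)c1` comes from compound 2 by a single change, methyl in place of chloro on an aromatic carbon, meta to a large group: methyl in place of chloro on an aromatic carbon.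

Within the data shown here, no measured pair shows this exchange, so the size of the step in this assay has no direct precedent. The expectation is no step beyond the scatter, and compound 3 may well read as a limit too. Any real movement is expected only towards stronger inhibition of growth, since compound 2 gives > 100000 nM as a limit. The step expected is an at least 1.4-fold lower number from compound 2 to compound 3 (0.15 log units; that floor lies within the scatter). For compound 3 the estimated value is 70000 nM, with an expected range from 5000 nM to 100000 nM.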

Compound 3, concentration for 50% growth inhibition: 138 nM
Beside the measured number, compound 3's estimate is 510-fold (2.71 log units) above it; measured number outside the range, below it.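

In this assay, among these compounds, methyl in place of chloro on an aromatic carbon, meta to a large group, gives the first step that can be read, and it is large: an at least 720-fold lower number from compound 2 to compound 3 (2.86 log units; beyond the scatter). Neither chloro nor methyl carries a ring, a hydrogen-bond donor, a hydrogen-bond acceptor or a net charge, yet the exchange at this one position separates a reading at the limit of the assay from a measured number, so growth inhibition in this pair depends strongly on which of the two groups sits there. Compound 2 stands at a limit and not at a number, so the step gives only a floor and its full size cannot be read: the limit of > 100000 nM in this assay, at which 1 of the 3 values shown sits.

The compounds shown leave open whether methyl itself is favoured or chloro alone is poorly tolerated, which a fluoro, methoxy, ethyl or amino group at the same position would help to separate. They also leave open whether the exchange carries the same weight on the core of compound 1, where a chloro group stands at this position.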